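Swapping Sulfamoyl for Methyl on the Aromatic Ring

The source may hold more compounds than are shown below. What is called first, only, known or untested is meant among the compounds shown, and "the series" means these compounds.

In a functional assay on RKO cells (Homo sapiens) for cytotoxicity, read by resazurin assay, with a stated time of 72 h (a lower number here means a stronger inhibitor, a higher number a weaker inhibitor), compound 1 `Cc1nccn1-c1csc(Nc2ccc(Br)cc2)n1` gives 30000 nM and compound 2 `Cc1nccn1-c1csc(Nc2ccc(S(N)(=O)=O)cc2)n1` gives 49000 nM while compound 3 `Cc1nc2ccccc2n1-c1csc(Nc2ccccc2)n1` gives 40000 nM and so compound 2 lies within the usual scatter of both others. Compound 4 `Cc1ccc(Nc2nc(-n3ccnc3C)cs2)cc1` is the next to consider. Its change from compound 2 is methyl in place of sulfamoyl on an aromatic carbon and in words it puts methyl in place of sulfamoyl on an aromatic carbon. For the measured compounds named here, the one measured step at that place is a 1.6-fold higher number from compound 1 to compound 2 (0.21 log units; within the scatter) for sulfamoyl in place of bromo, which lies within the scatter, so no step beyond the scatter is expected in this assay for this change. Going by the values given here, no methyl compound has been measured yet, so the range stays wide. The estimated step is a 1.4-fold lower number from compound 2 to compound 4 (0.15 log units; within the scatter) and it stays within the scatter. Compound 4 is expected at 35000 nM with a range from 15000 nM to 70000 nM in this estimate.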

Compound 4, half-maximal inhibitory concentration: 450 nM
Compound 4: middle estimate off by 78-fold (1.89 log units), on the high side; measured number outside the range, below it.
By their numbers in this assay, from the lowest: compound 4; then compounds 1, 3 and 2 (each within the scatter of the next).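

In this assay the group at this place on the aromatic ring proves decisive: methyl in place of sulfamoyl gives a 110-fold lower number from compound 2 to compound 4 (2.04 log units; beyond the scatter) and methyl in place of bromo gives a 67-fold lower number from compound 1 to compound 4 (1.82 log units; beyond the scatter) on the same core. For the compounds shown here, the swap between bromo and sulfamoyl had stayed within the scatter, so it gave no sign that this position could move the number so far. Nothing measured here explains why methyl stands apart from the other two groups. Still open, on these data alone, is whether a longer chain such as ethyl, a methoxy group or an amine at this place would behave like methyl or like bromo and sulfamoyl.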